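Cyclopentylcarbamoyl for ethoxycarbonyl: cytotoxicity outlook for compound 3

A few compounds are considered here, and "the series" means these few. Any claim that something is new, unique, unknown or untested is made for them only; others in the source may bear on it.

Measured in an ADME assay on Huh-7 cells (Homo sapiens) for cytotoxicity, read by MTT assay, with a stated time of 72 h; on this read-out lower numbers stand for higher toxicity in this test and higher numbers for lower toxicity in this test:
compound 1, `CCOC(=O)c1sc2nc(-c3ccccc3)cc(C(F)(F)F)c2c1N`: > 20000 nM
compound 2, `CCOC(=O)c1sc2nc(C3CC3)cc(C(F)(F)F)c2c1N`: > 20000 nM

For compound 2 the entry > 20000 nM is a limit of the assay and not a number. For compound 1 the entry > 20000 nM is likewise a limit. Compound 1 thus stands only at a limit in this assay, and the limit of > 20000 nM in this assay, at which 2 of the 2 values shown sit, covers every value shown. Among the compounds with values here, the single measured step, a step that the two limits leave unreadable from compound 1 to compound 2, cannot be read because both ends rest at the limit of > 20000 nM in this assay, at which 2 of the 2 values shown sit. Compound 3, `Nc1c(C(=O)NC2CCCC2)sc2nc(-c3ccccc3)cc(C(F)(F)F)c12`, differs from compound 1 by cyclopentylamino in place of ethoxy on a carbonyl carbon; cut one bond further out this reads ethoxycarbonyl to cyclopentylcarbamoyl. Within the data shown here, no measured step bears on this change, and the series has so far produced no number at all. The expectation is that compound 3 also rests at the limit, so the step that the limit leaves unreadable from compound 1 to compound 3 in this assay is estimated as nothing beyond the scatter. Compound 3 is estimated at 25000 nM, range 8000 nM to 80000 nM.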

Compound 3, half-maximal cytotoxic concentration: > 20000 nM
Compound 3: only a limit was reported (the forecaster's own chance of this, stated with the estimate: 75%); the middle value lies beyond the limit too.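

No step can be read from compound 1 to compound 3 in this assay, since both compounds rest at a limit and not at a number: the limit of > 20000 nM in this assay, at which 3 of the 3 values shown sit.

The compounds shown leave open whether any change on the shared core gives a measurable cytotoxic concentration in this assay, and how these three compounds would rank.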